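The source may hold more compounds than are shown below. What is called first, only, known or untested is meant among the compounds shown, and "the series" means these compounds.

Series notes, anilide variation on the shared core of compound 1 `Cc1ccc(NC(=O)Nc2cccc(CNc3nccnc3Cl)c2)c(C)c1`. Within the data shown here, in a functional assay on MGC-803 cells (Homo sapiens) for antiproliferative activity, read by MTT assay, with a stated time of 48 h (on this read-out higher numbers stand for weaker inhibition and lower numbers for stronger inhibition), compound 1 gives 10100 nM, the second highest of the three numbers so far. Compound 2 `O=C(Nc1ccc(C(F)(F)F)cc1)Nc1cccc(CNc2nccnc2Cl)c1` gives 6910 nM, within the scatter of compound 1, so no order between the two can be read. Compound 3 `O=C(Nc1cccc(CNc2nccnc2Cl)c1)Nc1cccc2ccccc12` gives 32700 nM, a gap from compound 1 that lies beyond the scatter.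

The next compound, compound 4 `Cc1ccc(NC(=O)Nc2cccc(CNc3nccnc3Cl)c2)cc1Cl`, differs from compound 1 by 3-chloro-4-methylphenyl in place of 2,4-dimethylphenyl on an amide-type nitrogen. Among the measured compounds shown here, no measured pair shows this exact change. For the measured compounds named here, the only guide is the small spread seen where compound 2 gives 6910 nM, within the scatter of compound 1, and the expectation rests on that. The expected step is a 1.4-fold lower number from compound 1 to compound 4 (0.16 log units; within the scatter), a slight move to a lower number that possibly does not lie beyond the scatter. For compound 4 the estimate is 7000 nM, with a range from 2500 nM to 20000 nM.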

Compound 4, half-maximal inhibitory concentration: 17500 nM
Compound 4: middle estimate off by 2.5-fold (0.40 log units), on the low side; the range from low to high includes it.
By their numbers in this assay, from the lowest: compounds 2, 1, 4 and 3 (each within the scatter of the next, the first and the last beyond it).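

In this assay, 3-chloro-4-methylphenyl in place of 2,4-dimethylphenyl on an amide-type nitrogen gives a 1.7-fold higher number from compound 1 to compound 4 (0.24 log units; within the scatter). Among these compounds, this is the first direct one-place reading at this position, and it shows that this exchange, which brings in a chlorine, does not produce a step beyond the scatter. No measurement at hand gives a reason for this step.

Still open, as far as these compounds go, is whether a carboxylic acid or an amine on this phenyl, or a longer alkyl chain in its place, would produce a step beyond the scatter.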